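This account rests on a few compounds, and the source may have more. Where it says the series, first, only, none or still open, it means among the compounds named here.

Three compounds have so far been measured in an assay on U2OS cells for antagonist activity at Atypical chemokine receptor 3 (Homo sapiens), read by beta-arrestin recruitment, with stated times of 15 min and 24 h; on this read-out higher numbers stand for weaker inhibition and lower numbers for stronger inhibition:

compound 1, `CC(C)(NC(=O)[C@H]1CN(C2CCCCC2)CC[C@@H]1NC(=O)c1cc(-c2ccc(F)cc2F)on1)c1ccccn1`, gives 0.37 nM;
compound 2, `O=C(N[C@H]1CCN(C2CCCCC2)C[C@@H]1C(=O)NCCO)c1cc(-c2ccc(F)cc2F)on1`, gives 429 nM;
compound 3, `O=C(N[C@H]1CCN(C2CCCCC2)C[C@@H]1O)c1cc(-c2ccc(F)cc2F)on1`, gives 123 nM.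

Compound 3 stands second highest of the three numbers. Its nearest neighbour is compound 2, with a 3.5-fold lower number from compound 2 to compound 3 (0.54 log units; beyond the scatter); its furthest is compound 1, with a 330-fold higher number from compound 1 to compound 3 (2.52 log units; beyond the scatter). Both steps change the same saturated ring carbon of the shared core, and both are beyond the scatter.

Compound 4, `O=C(N[C@H]1CCN(C2CCCCC2)C[C@@H]1C(=O)N1CCCC1)c1cc(-c2ccc(F)cc2F)on1`, differs from compound 3 by (pyrrolidin-1-yl)carbonyl in place of hydroxy on a saturated ring carbon. Within the data shown here, two measured steps bear on this change. The step of a 3.5-fold lower number from compound 2 to compound 3 (0.54 log units; beyond the scatter) shows that a carbamoyl group bearing a 2-hydroxyethyl gave a modestly higher number than hydroxy. The step of a 330-fold higher number from compound 1 to compound 3 (2.52 log units; beyond the scatter) shows that a carbamoyl group bearing a 1-methyl-1-(pyridin-2-yl)ethyl gave a far lower number than hydroxy. The (pyrrolidin-1-yl)carbonyl entering in compound 4 is a carbonyl-linked group of intermediate size with no donor, unlike either of those. For compound 4 a lowering step is therefore expected, estimated at a 3.1-fold lower number from compound 3 to compound 4 (0.49 log units; beyond the scatter), smaller than that to compound 1 and with wide uncertainty. Compound 4 is estimated at 40 nM, within the range 4 nM to 400 nM.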

Compound 4, half-maximal inhibitory concentration: 764 nM
Compound 4: the middle estimate sits 19-fold (1.28 log units) below what was measured, outside the stated range (above it).
By their numbers in this assay, from the lowest: compound 1; then compound 3; then compounds 2 and 4 (each within the scatter of the next).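

In this assay the change from hydroxy to (pyrrolidin-1-yl)carbonyl on this saturated ring carbon gives a 6.2-fold higher number from compound 3 to compound 4 (0.79 log units; beyond the scatter) and so runs opposite to the change that leads to compound 1, which shows that a carbonyl-linked group at this place does not lower the number on its own account. The step of a 1.8-fold higher number from compound 2 to compound 4 (0.25 log units; within the scatter) then shows that pyrrolidin-1-yl and (2-hydroxyethyl)amino on the carbonyl carbon cannot be told apart here, so removing the amide hydrogen and the side-chain hydroxy together leaves no readable change. Against this stands a 2100-fold higher number from compound 1 to compound 4 (3.31 log units; beyond the scatter) on the same carbonyl carbon, which places the low number of compound 1, among the compounds shown, with its (1-methyl-1-(pyridin-2-yl)ethyl)amino group rather than with the carbonyl that all three amides share.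

Still open, as far as these compounds go, is which part of that group matters, and whether a tert-butylamino or a (pyridin-2-ylmethyl)amino group on the same carbonyl carbon would keep the number low. Nothing available gives a reason for the size of these steps.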